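This account rests on a few compounds, and the source may have more. Where it says the series, first, only, none or still open, it means among the compounds named here.

Working notes on the series. In a functional assay on the whole organism (strain Wistar) for inhibition, with Rattus norvegicus as the target, read by paw edema, with stated times of 60 min and 6 h, at a dose of 100 mg/kg by the oral route (a higher number here means more inhibition at the dose given (going by the name of the read-out), a lower number less inhibition), compound 1 `CCCNC(=O)CC1CCc2cc(OC)c(OC)cc21` gives 22.2%, compound 2 `COc1cc2c(cc1OC)C(CC(=O)NC(C)(C)C)CC2` gives 31.5% and compound 3 `COc1cc2c(cc1OC)C(CC(=O)NCc1ccccc1)CC2` gives 30.6%. Compound 3 thus stands second highest of the three numbers; its nearest neighbour is compound 2 and the gap to compound 1 is also within the scatter. Every measured step changes only the group on the amide nitrogen: a number 9.3 percentage points higher from compound 1 to compound 2 (within the scatter), a number 8.4 percentage points higher from compound 1 to compound 3 (within the scatter) and a number 0.9 percentage points lower from compound 2 to compound 3 (within the scatter), none of them beyond the scatter. Compound 4 `COc1cc2c(cc1OC)C(CC(=O)N1CCCC1)CC2` continues this pattern, with pyrrolidin-1-yl in place of benzylamino on a carbonyl carbon. The step from compound 2 to compound 3 bears most directly, and it was flat. No step beyond the scatter is therefore expected in this assay; the expected change is a number 2.6 percentage points lower from compound 3 to compound 4 (within the scatter). Compound 4 is estimated at 28%, in a range from 15% to 42%.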

Compound 4, a percentage reported as inhibition, in the whole organism at one dose (the size of the read-out at that dose, not a potency): 22.2%
The estimate for compound 4 lay 5.8 percentage points above the measured number, within the range that was stated.
By their numbers in this assay, from the lowest: compounds 1, 4, 3 and 2 (each within the scatter of the next).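

With pyrrolidin-1-yl on the carbonyl carbon, the amide nitrogen no longer carries a hydrogen-bond donor, and the number in this assay still shows no step beyond the scatter: a number 8.4 percentage points lower from compound 3 to compound 4 (within the scatter) and a number 9.3 percentage points lower from compound 2 to compound 4 (within the scatter) and no change at the digits printed from compound 1 to compound 4 (within the scatter) all say so. A ring closed on that nitrogen therefore reads like the open groups, benzylamino included. Nothing available explains these numbers.

Still open, on these data alone, is whether morpholin-4-yl, hexylamino or a carboxylic acid in place of the amide on this carbonyl carbon would give a step beyond the scatter. All four compounds lie within the scatter of one another, so no group here is yet separated from the rest.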